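The source may report more compounds than this note shows. Statements on the series, on what has been measured and on what is new or still open speak of the compounds shown alone.

The three compounds measured so far:

Compound 1 `Cc1nc(S(C)(=O)=O)ccc1Oc1ncnc(OC2CCN(C(=O)OC(C)(C)C(F)(F)F)CC2)c1F` gives 79% in a functional assay on isolated protein for inhibition of Glucose-dependent insulinotropic receptor (Rattus norvegicus), read by HTRF and cAMP accumulation; a lower number here means a smaller maximal response, a higher number a larger maximal response.
Compound 2 `CCC1(OC(=O)N2CCC(Oc3ncnc(Oc4ccc(S(C)(=O)=O)nc4C)c3F)CC2)CC1` gives 83% in this assay.
Compound 3 `Cc1nc(S(C)(=O)=O)ccc1Oc1ncnc(OC2CCN(C(=O)SC(C)C)CC2)c1F` gives 81% in this assay.

All three share one core and differ only in the group on the carbonyl carbon attached to the ring nitrogen. Compound 3 stands in the middle of the three numbers: its nearest neighbour is compound 1, with a number 2 percentage points higher from compound 1 to compound 3 (within the scatter), and its furthest is compound 2, with a number 2 percentage points lower from compound 2 to compound 3 (within the scatter), so no two of the three are separated by more than the scatter.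

Compound 4 `Cc1nc(S(C)(=O)=O)ccc1Oc1ncnc(OC2CCN(C(=O)C3(F)CCC3)CC2)c1F` follows from compound 3 by a group of 5 heavy atoms (4 carbon, 1 fluorine; one four-membered non-aromatic ring of carbon only) in place of a group of 4 heavy atoms (3 carbon, 1 sulfur; no ring), on a carbonyl carbon.

Among the compounds with values here, three steps bear on this change, all at the same carbonyl carbon: a number 4 percentage points higher from compound 1 to compound 2 (within the scatter), a number 2 percentage points higher from compound 1 to compound 3 (within the scatter) and a number 2 percentage points lower from compound 2 to compound 3 (within the scatter). Each of them swaps one group for another at this position and each stays within the scatter. Within the data shown here, no step among the measured compounds tells anything about a fluorine-bearing four-membered ring at this carbon, so the expectation rests only on the observation that this position has so far tolerated three different groups without a shift in this assay.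

Compound 4 is therefore expected to show no change at the digits printed from compound 3 to compound 4 (within the scatter) in this assay. The estimate for compound 4 in this assay is 81%, with a range from 71% to 91%.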

Compound 4, largest response reached (reported as efficacy), in percent of the reference or control that the assay uses: 91%
For compound 4 the middle estimate is 10 percentage points below the measured one; low and high end bracket the measured number.
By their numbers in this assay, from the lowest: compounds 1, 3, 2 and 4 (each within the scatter of the next, the first and the last beyond it).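

At the carbonyl carbon, the fluorine-bearing four-membered ring of compound 4 joins this carbon through a ring carbon, whereas the groups in compounds 1, 2 and 3 join it through oxygen or sulfur, and this different group is accepted in this assay with a number 10 percentage points higher from compound 3 to compound 4 (within the scatter) and a number 8 percentage points higher from compound 2 to compound 4 (within the scatter) as the steps to the two nearest compounds. Within the data shown here, the step of a number 12 percentage points higher from compound 1 to compound 4 (beyond the scatter) is the first at this position to pass beyond the usual scatter, so the position no longer reads as entirely flat, although the separation is modest and holds for this one pair alone, with compounds 2 and 3 going against any broader separation of compound 4 from the rest. No measurement at hand offers an explanation for this step.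

On these data alone, what remains open is whether the step from compound 1 belongs to the fluorine, to the four-membered ring or to the carbon link to the carbonyl. As far as these compounds go, how a plain cyclobutyl group, a tert-butyl chain or a dimethylamino group on this carbonyl carbon would read in this assay also stays unknown.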